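This account rests on a few compounds, and the source may have more. Where it says the series, first, only, none or still open, it means among the compounds named here.

Compound 1 `CCCC#Cc1cc2ccccc2nc1N` is the starting point of this small series; in an assay on HEK-Blue hTLR8 cells for agonist activity at Toll-like receptor 8 (Homo sapiens), read by reporter gene assay and spectrophotometry (a lower number here means that less compound is needed, a higher number that more compound is needed for the effect), compound 1 gives 13000 nM. Compound 2 `CCCCSc1cc2ccccc2nc1N` carries butylsulfanyl where compound 1 carries pent-1-yn-1-yl, and in this assay compound 2 gives 4160 nM; the move is a 3.1-fold lower number from compound 1 to compound 2 (0.49 log units; beyond the scatter). Within the data shown here, compound 2 thus stands at the lowest of the two numbers measured so far, with compound 1 as its only point of comparison. Compound 3 `C=CCCCc1cc2ccccc2nc1N` alters the same aromatic carbon once more: pent-4-en-1-yl in place of butylsulfanyl on an aromatic carbon. Among the measured compounds shown here, only one measured step bears on this change, namely a 3.1-fold lower number from compound 1 to compound 2 (0.49 log units; beyond the scatter), which went from a chain of carbon alone to a chain bearing sulfur; compound 3 returns to a chain of carbon alone, though one with a double bond rather than the triple bond of compound 1. For the measured compounds named here, a modest rise toward the number of compound 1 is therefore expected, while the single comparison leaves the direction far from certain. Compound 3 is expected to give 7000 nM in this assay, within 2500 nM to 20000 nM, which would amount to a 1.7-fold higher number from compound 2 to compound 3 (0.23 log units; within the scatter).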

Compound 3, half-maximal effective concentration: 490 nM
Compound 3: the middle estimate sits 14-fold (1.15 log units) above what was measured; measured number below the stated range.
By their numbers in this assay, from the lowest: compound 3; then compound 2; then compound 1.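

In this assay, the aromatic carbon ortho to the amino group turns out to respond far more strongly than the first step alone could show: with 5 heavy atoms in the chain both before and after, pent-4-en-1-yl in place of butylsulfanyl brings an 8.5-fold lower number from compound 2 to compound 3 (0.93 log units; beyond the scatter) and so moves compound 3 clearly past both earlier compounds. Set against pent-1-yn-1-yl, the same chain brings a 27-fold lower number from compound 1 to compound 3 (1.42 log units; beyond the scatter) as the largest step in this small series, which shows that the kind of bonding within a chain of carbon alone can matter a great deal at this position. A simple reading in which a chain of carbon alone does better or worse than the sulfur chain therefore fails, since compound 1 and compound 3 both carry carbon chains yet lie on opposite sides of compound 2 in the order. No supporting data are available here to account for these differences.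

The compounds shown leave open how a saturated pentyl chain, which would separate the part played by the double bond from that of the chain itself, would compare at this carbon. They also leave open how a longer chain, a shorter chain, or a chain ending in an amine would behave there, and whether the double bond matters at the end of the chain or would matter equally elsewhere along it.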